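A few compounds are considered here, and "the series" means these few. Any claim that something is new, unique, unknown or untested is made for them only; others in the source may bear on it.

Measured so far:
- compound 1, `CCCC(Nc1ccc(-n2cc(C(F)(F)F)cn2)nc1)c1ccc(C(=O)NCCC(=O)O)cc1`: 2.1
- compound 2, `CCCC(Oc1ccc(-n2cc(C(F)(F)F)c(C)n2)cc1)c1ccc(C(=O)NCCC(=O)O)cc1`: 2.8
- compound 3, `CCCC(Nc1ccc(-n2cnc(C(F)(F)F)c2)cc1)c1ccc(C(=O)NCCC(=O)O)cc1`: 1.3

Of the compounds shown here, three have been measured in a physicochemical assay for lipophilicity, using the shake flask method, at pH 7.4; a lower number here means a more polar compound, a higher number a more lipophilic compound. Compound 2 gives the highest of the three numbers, 2.8. Its nearest neighbour on the numbers is compound 1, whose value of 2.1 lies lower by a gap beyond the scatter; the furthest is compound 3, whose value of 1.3 lies lower by a larger gap, also beyond the scatter. Among the compounds with values here, no pair among the three differs in only one place, so none of these gaps can be read as a single-change step.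

The next compound, compound 4, `CCCC(Oc1ccc(-n2cc(C(F)(F)F)cn2)cc1)c1ccc(C(=O)NCCC(=O)O)cc1`, differs from compound 2 in one place: hydrogen in place of methyl on an aromatic carbon. Cut one bond further out, the change reads 3-methyl-4-(trifluoromethyl)-1H-pyrazol-1-yl to 4-(trifluoromethyl)-1H-pyrazol-1-yl. Nothing measured in this series shows this particular step, so the expectation rests on the size of the group that leaves, one heavy atom with no ring, no donors and no acceptors.

The expected step is a number 0.40 log units lower from compound 2 to compound 4 (beyond the scatter), a small fall in the distribution coefficient, at the edge of the scatter. Compound 4 is therefore expected to give about 2.4, within 2 to 2.8.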

Compound 4, distribution coefficient: 2.4
Estimate against measurement, compound 4: no gap at the digits printed; the range from low to high includes it.
By their numbers in this assay, from the lowest: compound 3; then compounds 1 and 4 (each within the scatter of the next); then compound 2.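

In this assay, the series now has its first reading of a single change: hydrogen in place of methyl on an aromatic carbon gives a number 0.40 log units lower from compound 2 to compound 4 (beyond the scatter), a modest step. Within the data shown here, it shows that the read-out responds to this one change at this position, on the five-membered aromatic ring with 2 nitrogen, next to the ring nitrogen and next to the ring atom that bears a trifluoromethyl group, something the earlier compounds could not show with no pair among them differing in only one place. The step rests on this single pair, and nothing measured here accounts for its size.

Open, on these data alone, is how a longer chain such as ethyl, or a nitrile or an amine, would read at this same position in place of the methyl, and so whether the number follows the size of the group at all. Also open, as far as these compounds go, is whether removing the methyl gives a step of similar size on the core of compound 1 or the core of compound 3, which differ from compound 4 in more than one place.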